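Selenium-benzyl group in place of methylsulfanyl on compound 1

The source may report more compounds than this note shows. Statements on the series, on what has been measured and on what is new or still open speak of the compounds shown alone.

Measured compounds:
compound 1 `CS/C(=N\C(=O)c1csc([N+](=O)[O-])c1)NC(=O)c1csc([N+](=O)[O-])c1` gives 56900 nM
compound 2 `O=C(/N=C(/NC(=O)c1cccs1)[Se]Cc1ccccc1)c1cccs1` gives 29500 nM
compound 3 `CS/C(=N\C(=O)c1cccs1)NC(=O)c1cccs1` gives 72600 nM

These three compounds were tested in a functional assay on K562 cells (Homo sapiens) for cytotoxicity, read by MTT assay, with a stated time of 72 h; a lower number here means a stronger inhibitor of growth, a higher number a weaker inhibitor of growth. Compound 1 stands second highest of the three numbers: its value and that of compound 3 lie within the scatter of each other, and so do its value and that of compound 2, so no order among them can be claimed.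

Compound 4 `O=C(/N=C(/NC(=O)c1csc([N+](=O)[O-])c1)[Se]Cc1ccccc1)c1csc([N+](=O)[O-])c1` has not been measured. It differs from compound 1 in one place: a group of 8 heavy atoms (7 carbon, 1 selenium; one six-membered aromatic ring of carbon only) in place of a group of 2 heavy atoms (1 carbon, 1 sulfur; no ring), on a carbon with a double bond to nitrogen. The same exchange, in the opposite direction, is seen between compound 2 and compound 3, where a 2.5-fold higher number from compound 2 to compound 3 (0.39 log units; beyond the scatter). Running that change backwards on compound 1 suggests a lower number for compound 4, of a modest size beyond the scatter. Among the measured compounds shown here, compound 1 and compound 3 differ elsewhere, and no step for that pair is available, so the transfer carries some uncertainty.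

Compound 4 is therefore expected to give 23000 nM, with a range from 10000 nM to 50000 nM. This estimate means a step of a 2.5-fold lower number from compound 1 to compound 4 (0.39 log units; beyond the scatter), expected to mirror the step seen from compound 2 to compound 3.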

Compound 4, concentration for 50% growth inhibition: 23500 nM
Estimate against measurement, compound 4: 1.0-fold (0.01 log units) below, within the range that was stated.
By their numbers in this assay, from the lowest: compounds 4, 2, 1 and 3 (each within the scatter of the next, the first and the last beyond it).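

Among the compounds shown here, until now, the exchange between methylsulfanyl and the selenium-benzyl group had been read on only one core. On a second core, in this assay, placing the selenium-benzyl group on the carbon with a double bond to nitrogen gives a 2.4-fold lower number from compound 1 to compound 4 (0.38 log units; beyond the scatter). The change therefore has nearly the same size on both cores, so at this carbon its effect on the number carries over between these two cores: the same change on two cores in this assay, a 2.5-fold higher number (0.39 log units; beyond the scatter) from compound 2 to compound 3 and a 2.4-fold higher number (0.38 log units; beyond the scatter) from compound 4 to compound 1, 1.0-fold (0.01 log units) apart, within the scatter of two such steps

The compounds shown cannot separate the part played by the selenium atom from that of the benzyl group, and a benzylsulfanyl or methylselanyl group at this carbon would be needed to tell them apart. They also leave open how an amine or a longer alkyl chain at this carbon would read, and whether the step holds in other cell types.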